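The source may hold more compounds than are shown below. What is called first, only, known or untested is meant among the compounds shown, and "the series" means these compounds.

The compounds here share one core and differ in a single side group. In a functional assay on LNCaP cells (Homo sapiens) for cytotoxicity, read by MTT assay, with a stated time of 72 h (a higher number here means a weaker inhibitor, a lower number a stronger inhibitor), compound 1 `NCCCNc1c(C(=O)NCc2ccc(F)cc2)nc(Br)c2cccnc12` gives "not determined" (no result reported), so it offers no number to compare. Compound 2 `CN(C)CCCNc1c(C(=O)NCc2ccc(F)cc2)nc(Br)c2cccnc12` gives 8000 nM, and compound 3 `N[C@H]1CC[C@H](Nc2c(C(=O)NCc3ccc(F)cc3)nc(Br)c3cccnc23)CC1` gives 5000 nM. Among the compounds with values here, only these two numbers exist, and the single measured step joining them is a 1.6-fold lower number from compound 2 to compound 3 (0.20 log units; within the scatter). Within the data shown here, compound 3 therefore cannot be told apart from its only measured neighbour.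

Compound 4 `O=C(NCc1ccc(F)cc1)c1nc(Br)c2cccnc2c1N1CCNCC1` is the next structure to test. It carries piperazin-1-yl in place of (4-aminocyclohexyl)amino on an aromatic carbon. The measured step bears on this change only loosely. It put 4-aminocyclohexyl in place of 3-(dimethylamino)propyl on a nitrogen, whereas here the whole group on the aromatic carbon is exchanged. Among the measured compounds shown here, still, it is the only guide, and it stayed within the scatter, so the expectation starts from compound 3 at 5000 nM and assumes no clear shift. The expected change in this assay is a 1.2-fold higher number from compound 3 to compound 4 (0.08 log units; within the scatter), which means no step beyond the scatter, though one measured step is thin support. For compound 4 the estimated value is 6000 nM, with an expected range from 2000 nM to 16000 nM.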

Compound 4, half-maximal inhibitory concentration: 4500 nM
For compound 4 the middle estimate is 1.3-fold (0.12 log units) above the measured one; the measured number falls inside the stated range.
By their numbers in this assay, from the lowest: compounds 4, 3 and 2 (each within the scatter of the next).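

In this assay piperazin-1-yl can replace (4-aminocyclohexyl)amino (a 1.1-fold lower number from compound 3 to compound 4 (0.05 log units; within the scatter)) and (3-(dimethylamino)propyl)amino (a 1.8-fold lower number from compound 2 to compound 4 (0.25 log units; within the scatter)) on this aromatic carbon, para to the bromo group, with no step beyond the scatter. This change reaches further than the earlier step: until now, each side group with a number was joined to the core through a nitrogen that carried a hydrogen, whereas compound 4 is joined through a ring nitrogen that carries none, and its ring holds hetero atoms and has no defined stereocentres. Among these compounds, then, neither that linking hydrogen nor the stereocentres of the cyclohexyl ring are required to keep the number in the same range, and nothing measured here accounts for how close the numbers lie.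

Within the data shown here, because every step so far stays within the scatter, it remains open whether any group at this position can move the number clearly in either direction. A morpholin-4-yl ring, which has an oxygen in place of the second ring nitrogen, or a carboxylic acid at the end of a longer chain, would test that further.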